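Ethynyl Substituent Changes on an Adenosine A3 Antagonist Core

A few compounds are considered here, and "the series" means these few. Any claim that something is new, unique, unknown or untested is made for them only; others in the source may bear on it.

Measured compounds:
compound 1, `CNC(=O)[C@@]12C[C@@H]1[C@@H](n1cnc3c(NC)nc(C#Cc4ccc(OC)cc4)nc31)[C@H](O)[C@@H]2O`, 0.63 nM
compound 2, `CNC(=O)[C@@]12C[C@@H]1[C@@H](n1cnc3c(NC)nc(C#Cc4cccnn4)nc31)[C@H](O)[C@@H]2O`, 3.53 nM
compound 3, `CNC(=O)[C@@]12C[C@@H]1[C@@H](n1cnc3c(NC)nc(C#Cc4cc5ccccc5o4)nc31)[C@H](O)[C@@H]2O`, 1.62 nM

All three share one core and differ only in the aromatic group on the triple-bonded carbon. In an assay on CHO cells for displacement of a labelled ligand from adenosine receptor A3 (Homo sapiens), read by scintillation counting, with a stated time of 60 min (a lower number here means a stronger inhibitor, a higher number a weaker inhibitor), compound 3 gives 1.62 nM, the second highest of the three numbers: it sits a 2.2-fold lower number from compound 2 to compound 3 (0.34 log units; beyond the scatter) and a 2.6-fold higher number from compound 1 to compound 3 (0.41 log units; beyond the scatter), both beyond the scatter. Compound 4, `CNC(=O)[C@@]12C[C@@H]1[C@@H](n1cnc3c(NC)nc(C#Cc4nccs4)nc31)[C@H](O)[C@@H]2O`, has not been measured; it differs from compound 3 by 1,3-thiazol-2-yl in place of 1-benzofuran-2-yl on a triple-bonded carbon.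

For the measured compounds named here, two measured steps bear on this change. Going from the six-membered heteroaryl of compound 2 to the benzofuran of compound 3 gave a 2.2-fold lower number from compound 2 to compound 3 (0.34 log units; beyond the scatter); going from the methoxyphenyl of compound 1 to the benzofuran gave a 2.6-fold higher number from compound 1 to compound 3 (0.41 log units; beyond the scatter). Compound 4 reverses the direction of the first of these, replacing the benzofuran with a small five-membered heteroaryl, so a modest rise in the number is expected, of a size near that step. Compound 4 is therefore estimated at 3 nM, with a range from 1.2 nM to 8 nM, which means an expected step of a 1.9-fold higher number from compound 3 to compound 4 (0.27 log units; within the scatter).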

Compound 4, inhibition constant: 2.1 nM
The estimate for compound 4 lay 1.4-fold (0.15 log units) above the measured number, within the range that was stated.
By their numbers in this assay, from the lowest: compound 1; then compounds 3, 4 and 2 (each within the scatter of the next, the first and the last beyond it).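

In this assay, exchanging 1-benzofuran-2-yl for 1,3-thiazol-2-yl removes the six-membered aromatic ring of carbon only, yet the result stays within the scatter, with a 1.3-fold higher number from compound 3 to compound 4 (0.11 log units; within the scatter); on this triple-bonded carbon, a single five-membered aromatic ring therefore serves as well as the larger group, as far as this read-out can tell. The step to the pyridazin-3-yl compound is also within the scatter, with a 1.7-fold lower number from compound 2 to compound 4 (0.23 log units; within the scatter), so compound 4 overlaps both compound 2 and compound 3 even though those two are separated beyond the scatter, while the 4-methoxyphenyl group keeps its edge, with a 3.3-fold higher number from compound 1 to compound 4 (0.52 log units; beyond the scatter). No measurement given here accounts for these differences.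

All the groups shown on this carbon are aromatic rings, so it remains open how an amine, a carboxylic acid or a longer alkyl chain ending in a hydroxyl group would fare there. On these data alone, with no plain phenyl among the compounds, it also remains open whether the standing of compound 1 depends on its methoxy group or on the phenyl ring alone.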